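This account rests on a few compounds, and the source may have more. Where it says the series, first, only, none or still open, it means among the compounds named here.

Of the compounds shown here, three built on one shared core have been measured in a functional assay on PC-3 cells (Homo sapiens) for cytotoxicity, read by MTT assay, with a stated time of 48 h; on this read-out lower numbers stand for stronger inhibition and higher numbers for weaker inhibition. Compound 1 `O=C(c1ccccc1)N1N=C(c2cc3ccccc3oc2=O)CC1c1ccccc1` gives 5870 nM, compound 2 `CCNCC(=O)N1N=C(c2cc3ccccc3oc2=O)CC1c1ccccc1` gives 5580 nM, and compound 3 `O=C(CN1CCCC1)N1N=C(c2cc3ccccc3oc2=O)CC1c1ccccc1` gives 50200 nM, the highest of the three numbers. Compound 4 `O=C(CN1CCC(O)CC1)N1N=C(c2cc3ccccc3oc2=O)CC1c1ccccc1` is not yet measured; it differs from compound 3 by 4-hydroxypiperidin-1-yl in place of pyrrolidin-1-yl on a saturated chain carbon bound to a carbonyl carbon. Within the data shown here, two measured steps bear on this: a 9.0-fold higher number from compound 2 to compound 3 (0.95 log units; beyond the scatter) and an 8.6-fold higher number from compound 1 to compound 3 (0.93 log units; beyond the scatter), so in both cases exchanging the pyrrolidin-1-yl group changed the number beyond the scatter. Compound 4 keeps a ring amine but brings 1 hydrogen-bond donor, as the ethylamino group of compound 2 does, so a moderate move back toward lower numbers is expected, with wide uncertainty. Compound 4 is estimated at 15000 nM, between 5000 nM and 50000 nM. The expected step is a 3.3-fold lower number from compound 3 to compound 4 (0.52 log units; beyond the scatter).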

Compound 4, half-maximal inhibitory concentration: "not active" (no number reported)
Compound 4 has no reported number here; the estimate stays without a comparison.
By their numbers in this assay, from the lowest: compounds 2 and 1 (each within the scatter of the next); then compound 3.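

In this assay, among these compounds, compound 4 is reported only as "not active", without a number, so no step from compound 3 to compound 4 can be read. How far apart these two compounds lie stays open, and nothing shown here explains the result.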